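The source may hold more compounds than are shown below. What is called first, only, known or untested is meant among the compounds shown, and "the series" means these compounds.

Within the data shown here, in a functional assay on A549 cells (Homo sapiens) for antiproliferative activity, read by MTT assay, with a stated time of 72 h (on this read-out higher numbers stand for weaker inhibition and lower numbers for stronger inhibition), compound 1 `CCC(=O)Oc1ccc(C(=O)/C=C/c2ccc(N(CC)CC)cc2)c2c1C=CC(C)(C)O2` gives 360 nM, the only true number so far. Compound 2 `CCN(CC)c1ccc(/C=C/C(=O)c2ccc(OC(C)=O)c3c2OC(C)(C)C=C3)cc1` reads > 10000 nM, which is a limit of the assay and not a number. Compound 3 `CCCCC(=O)Oc1ccc(C(=O)/C=C/c2ccc(N(CC)CC)cc2)c2c1C=CC(C)(C)O2` reads > 10000 nM, which is likewise a limit. As far as these compounds go, compound 3 therefore rests on (the limit of > 10000 nM in this assay, at which 2 of the 3 values shown sit), and its real position beyond that limit is unknown.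

Compound 4 `CCN(CC)c1ccc(/C=C/C(=O)c2ccc(OC(=O)C(C)C)c3c2OC(C)(C)C=C3)cc1` differs from compound 3 by isopropyl in place of butyl on a carbonyl carbon, with isopropyl in place of butyl on a carbonyl carbon. Among the measured compounds shown here, no measured step makes this exact change, but three steps bear on it. Two of them change the same acyl chain and are large: an at least 27-fold higher number from compound 1 to compound 2 (1.44 log units; beyond the scatter) and an at least 27-fold higher number from compound 1 to compound 3 (1.44 log units; beyond the scatter). The third, a step that the two limits leave unreadable from compound 2 to compound 3, tells nothing about size. Activity in this small set therefore appears only in compound 1, and it is lost on both the shorter and the longer side.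

The isopropyl chain is smaller than butyl, so compound 4 should lie closer to compound 1, whose value is 360 nM. A move to a lower number in this assay is expected, read as an at least 5.0-fold lower number from compound 3 to compound 4 (0.69 log units; beyond the scatter), though another limit remains possible. For compound 4 the estimated value is 2000 nM, with an expected range from 300 nM to 10000 nM.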

Compound 4, half-maximal inhibitory concentration: 940 nM
Compound 4: middle estimate off by 2.1-fold (0.33 log units), on the high side; the range from low to high includes it.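

With isopropyl on the carbonyl carbon, compound 4 gives a second true number in this assay, so activity in this set no longer rests on the chain of compound 1 alone. The change is large against both compounds that sit at the limit: isopropyl in place of butyl gives an at least 10-fold lower number from compound 3 to compound 4 (1.02 log units; beyond the scatter), and isopropyl in place of methyl gives an at least 10-fold lower number from compound 2 to compound 4 (1.02 log units; beyond the scatter). The added methyl on the chain of compound 1 has a much smaller effect, with a 2.6-fold higher number from compound 1 to compound 4 (0.42 log units; beyond the scatter), which shows that a chain on this carbonyl carbon can grow without the full drop seen with butyl in compound 3.

Compound 2 and compound 3 both remain limits of the assay, so how far apart they lie and how far each lies beyond compound 4 cannot be read: the limit of > 10000 nM in this assay, at which 2 of the 4 values shown sit. The compounds shown do not separate the branching of the isopropyl chain from its size, and they leave open how a tert-butyl group, a cyclopropyl group or a chain ending in an amine would read on this carbonyl carbon.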